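This account rests on a few compounds, and the source may have more. Where it says the series, first, only, none or still open, it means among the compounds named here.

Working notes on the series. The shared core is that of compound 1 `O=C(Nc1cc(C(F)(F)F)ccc1N1CCCC1)c1cccnc1Cl`. In a functional assay on HL-60 cells (Homo sapiens) for cytotoxicity, read by MTT assay, with a stated time of 48 h (a higher number here means a weaker inhibitor, a lower number a stronger inhibitor), compound 1 gives "not active" (no number reported). Going by the values given here, compound 2 `CCN(CC)c1ccc(C(F)(F)F)cc1NC(=O)c1cccnc1` carries a diethylamino group and a pyridin-3-yl carbonyl; in this assay compound 2 gives 71000 nM, one of only two numbers recorded so far, the other belonging to compound 3 and lying within the scatter of it. Compound 3 `O=C(Nc1cc(C(F)(F)F)ccc1NC1CCCCC1)c1cccnc1` has cyclohexylamino in place of diethylamino, and in this assay compound 3 gives 48300 nM. The step of a 1.5-fold lower number from compound 2 to compound 3 (0.17 log units; within the scatter) shows that this change on the amine side leaves the read-out essentially where it was. Compound 1 differs from compound 2 in two places at once, so its outcome shows only that that combination produced no number.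

Compound 4 `CCN(CC)c1ccc(C(F)(F)F)cc1NC(=O)c1ccccc1` is derived from compound 2 by phenyl in place of pyridin-3-yl on a carbonyl carbon. Among the compounds with values here, no measured step touches the carbonyl side; the single measured step concerns a different position and stayed within the scatter. There is therefore no basis for expecting a shift in either direction. For compound 4 the expected step is no change at the digits printed from compound 2 to compound 4 (within the scatter), nothing beyond the scatter. For compound 4 the estimate in this assay is 71000 nM, with a range from 25000 nM to 200000 nM.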

Compound 4, half-maximal inhibitory concentration: "not active" (no number reported)
Nothing numeric was reported for compound 4; there is nothing to compare the estimate with.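

In this assay, going by these compounds alone, compound 4 gives "not active" (no number reported), and no step from compound 2 to compound 4 can be read. The compounds shown leave open how far phenyl in place of pyridin-3-yl on a carbonyl carbon shifts the read-out. No measurement at hand offers an explanation for this result.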